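Ring-amine substituents: butyl against amides

The compounds below may be only part of what the source reports. "The series", "measured", "known", "first", "only" and "open" are said of these compounds alone.

Measured so far in this assay:
compound 1, `CCCCN1CCc2nc(C#Cc3ccccc3)sc2C1`: 110 nM
compound 2, `O=C(C1CC1)N1CCc2nc(C#Cc3ccccc3)sc2C1`: > 10000 nM
compound 3, `COC1CC(C(=O)N2CCc3nc(C#Cc4ccccc4)sc3C2)C1`: 640 nM
compound 4, `O=C(CC1CCOCC1)N1CCc2nc(C#Cc3ccccc3)sc2C1`: not yet measured

All numbers come from an assay on HEK293 cells for positive allosteric modulation of metabotropic glutamate receptor 5 (Homo sapiens), read by FLIPR, with a stated time of 1 h; a lower number here means that less compound is needed, a higher number that more compound is needed for the effect. Compound 1, with butyl on the amine nitrogen in the ring, gives 110 nM. The value of compound 2 is a limit of the assay, (the limit of > 10000 nM in this assay, at which 1 of the 3 values shown sits). Compound 3 gives 640 nM, the higher of the two actual numbers, and the step from the butyl compound is a 5.8-fold higher number from compound 1 to compound 3 (0.76 log units; beyond the scatter).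

Compound 4 differs from compound 3 only at the carbonyl carbon: (oxan-4-yl)methyl in place of 3-methoxycyclobutyl on a carbonyl carbon

Within the data shown here, two measured steps bear on this. The exchange of butyl for an amide gave an at least 90-fold higher number from compound 1 to compound 2 (1.95 log units; beyond the scatter), a large loss. Within the amides, the exchange on the carbonyl carbon gave an at least 15-fold lower number from compound 2 to compound 3 (1.19 log units; beyond the scatter), recovering much of it with a larger, ether-bearing group. Compound 4 keeps the amide and an ether-bearing group of similar size, so a number close to that of compound 3 is expected, within the scatter or a modest rise. Compound 4 is therefore estimated at 900 nM, with a range from 200 nM to 5000 nM. The expected step is a 1.4-fold higher number from compound 3 to compound 4 (0.15 log units; within the scatter).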

Compound 4, half-maximal effective concentration: 470 nM
For compound 4 the middle estimate is 1.9-fold (0.28 log units) above the measured one, within the range that was stated.
By their numbers in this assay, from the lowest: compound 1; then compounds 4 and 3 (each within the scatter of the next). At a limit, above all of these: compound 2.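

In this assay, the place on the carbonyl carbon accepts a four-membered carbon ring with a methoxy group or a six-membered ring with one hetero atom on a methyl link, with no readable difference between them: a 1.4-fold lower number from compound 3 to compound 4 (0.13 log units; within the scatter). The recovery from the cyclopropyl amide now holds for two different ether-bearing groups, not just one: an at least 21-fold lower number from compound 2 to compound 4 (1.32 log units; beyond the scatter). The value of compound 2 is a limit, so that step has only a lower bound: the limit of > 10000 nM in this assay, at which 1 of the 4 values shown sits.

As far as these compounds go, whether the ring oxygen matters stays open, and a cyclohexylmethyl group at the same carbonyl carbon would test it against an all-carbon ring. Also open, from the compounds shown here alone, is whether any amide can match compound 1 at 110 nM, or whether a group carrying an amine, such as piperidin-4-ylmethyl, would behave differently.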